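Piperazine dithiocarbamate benzamides: aryl swap on the ring nitrogen

The source may report more compounds than this note shows. Statements on the series, on what has been measured and on what is new or still open speak of the compounds shown alone.

Of the compounds shown here, two have numbers so far. Compound 1 `Nc1ccccc1NC(=O)c1ccc(CSC(=S)N2CCN(C(c3ccccc3)c3ccccc3)CC2)cc1` carries a diphenylmethyl group on the ring nitrogen and in a functional assay on A-375 cells (Homo sapiens) for antiproliferative activity, read by CCK-8 assay, with a stated time of 72 h, tested at 8 uM (on this read-out higher numbers stand for a stronger effect at the one concentration tested and lower numbers for a weaker effect), compound 1 gives 8.4%. Compound 2 `N#Cc1ccc(N2CCN(C(=S)SCc3ccc(C(=O)Nc4ccccc4N)cc3)CC2)cc1` carries a 4-cyanophenyl group at the same place and in this assay compound 2 gives 62.9%, the higher of the two numbers, and the gap to compound 1 lies beyond the scatter. Compound 3 `Nc1ccccc1NC(=O)c1ccc(CSC(=S)N2CCN(c3ccncc3)CC2)cc1` has not yet been measured; it differs from compound 2 in one place: pyridin-4-yl in place of 4-cyanophenyl on an amine nitrogen in a ring. Within the data shown here, no measured pair shows this step, so its size is not known from the data. The expectation is a moderate drop, a number 22.9 percentage points lower from compound 2 to compound 3 (beyond the scatter), short of the level of compound 1. In this assay compound 3 is estimated at 40%, with a range from 15% to 65%.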

Compound 3, a percentage reported as inhibition, at one concentration (the size of the read-out at that concentration, not a potency): 90.7%
For compound 3 the middle estimate is 50.7 percentage points below the measured one; the measured number lies above the stated range.
By their numbers in this assay, from the lowest: compound 1; then compound 2; then compound 3.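

In this assay, pyridin-4-yl in place of 4-cyanophenyl on the amine nitrogen in the ring gives a number 27.8 percentage points higher from compound 2 to compound 3 (beyond the scatter), so this position can carry more than the level seen with 4-cyanophenyl. The step removes the triple bond outside aromatic rings and brings a hetero atom into the six-membered aromatic ring, while the count of hydrogen-bond acceptors in the group stays the same, so a nitrile is not required here for a high number on this read-out. No measurement on hand says which part of the swap accounts for the step.

Going by these compounds, whether the ring nitrogen of pyridin-4-yl matters remains open, and a plain phenyl or a pyridin-3-yl group at this place would separate that from the loss of the nitrile. Also open, on these data alone, is whether a pyrimidin-2-yl group keeps the number at this level.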